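A few compounds are considered here, and "the series" means these few. Any claim that something is new, unique, unknown or untested is made for them only; others in the source may bear on it.

Compound 1 `Cc1nc(N(C)C(=O)NC(=O)c2c(F)cccc2F)sc1C(=O)N/N=C/c1ccccc1C(F)(F)F` gives 6.51 ug/mL.
Compound 2 `CN(C(=O)NC(=O)c1c(F)cccc1F)c1nc(C(F)(F)F)c(C(=O)N/N=C/c2ccccc2C(F)(F)F)s1` gives 19.6 ug/mL.
Compound 3 `CN(C(=O)NC(=O)c1cccc(C(F)(F)F)c1)c1nc(C(F)(F)F)c(C(=O)N/N=C/c2ccc(C(F)(F)F)cc2)s1` gives 7.35 ug/mL.

In a functional assay on HeLa cells (Homo sapiens) for inhibition, read by MTT assay, with a stated time of 72 h (on this read-out higher numbers stand for weaker inhibition and lower numbers for stronger inhibition), compound 1 stands at the lowest of the three numbers, with 6.51 ug/mL. Compound 3 sits nearest to it, at 7.35 ug/mL, a gap within the scatter, so the two cannot be ordered. Compound 2 stands furthest, at 19.6 ug/mL, a gap beyond the scatter.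

Compound 4 `Cc1nc(N(C)C(=O)NC(=O)c2c(F)cccc2F)sc1C(=O)N/N=C/c1cccc(C(F)(F)F)c1` has not yet been measured in this assay. It differs from compound 1 in one place: 3-(trifluoromethyl)phenyl in place of 2-(trifluoromethyl)phenyl on a carbon with a double bond to nitrogen

Within the data shown here, the one measured step, a 3.0-fold higher number from compound 1 to compound 2 (0.48 log units; beyond the scatter), concerns trifluoromethyl in place of methyl on an aromatic carbon of the shared core, not the group on the carbon with a double bond to nitrogen. It therefore does not bear on the change from compound 1 to compound 4. Compound 3 carries a different pattern of trifluoromethyl groups and differs from compound 1 in more than one place, so its value alone is shown and no step is drawn from it.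

Among the measured compounds shown here, with no step bearing on this change, compound 4 is expected to land close to compound 1, an estimated step of a 1.1-fold higher number from compound 1 to compound 4 (0.03 log units; within the scatter), within the scatter in either direction. Compound 4 is thus estimated at 7 ug/mL, with a range from 3 ug/mL to 16 ug/mL.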

Compound 4, half-maximal inhibitory concentration: 26.8 ug/mL
Compound 4: middle estimate off by 3.8-fold (0.58 log units), on the low side, and the stated range ends below it.
By their numbers in this assay, from the lowest: compounds 1 and 3 (each within the scatter of the next); then compounds 2 and 4 (each within the scatter of the next).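

Exchanging 2-(trifluoromethyl)phenyl for 3-(trifluoromethyl)phenyl on a carbon with a double bond to nitrogen changes only how the same atoms are joined, yet in this assay it gives a 4.1-fold higher number from compound 1 to compound 4 (0.61 log units; beyond the scatter). Among these compounds, the only step available before this one concerned the aromatic carbon of the shared core, so this is the first direct sign that the number also responds to the group on the carbon with a double bond to nitrogen, and here to the placement of trifluoromethyl within that group. Nothing available accounts for this difference between the two isomeric groups.

The compounds shown leave open how a plain phenyl group, or a phenyl group carrying a nitrile or a methoxy group instead of trifluoromethyl, would read at this place on the core of compound 1. They also leave open whether the same exchange would give a step of similar size on the core of compound 2, which has trifluoromethyl in place of methyl on an aromatic carbon.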